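The compounds below may be only part of what the source reports. "The series", "measured", "known", "first", "only" and "open" are said of these compounds alone.

Three compounds share one core, an amide joined to a hydroxylated bicyclic ring system, and differ only in the aromatic group on the amide nitrogen. Compound 1 `COc1ccc(NC(=O)c2ccc3cccc(O)c3n2)cc1` carries a methoxyphenyl group, compound 2 `O=C(Nc1ccccc1F)c1ccc2cccc(O)c2n1` a 2-fluorophenyl group, and compound 3 `O=C(Nc1cccc(F)c1)c1ccc2cccc(O)c2n1` a 3-fluorophenyl group. In a physicochemical assay for lipophilicity, read by HPLC (a higher number here means a more lipophilic compound, a lower number a more polar compound), compound 1 gives 2.5, compound 2 gives 2.5, and compound 3 gives 2.5. Within the data shown here, compound 2 therefore stands level with both compound 1 and compound 3, and the one step that can be read directly, no change at the digits printed from compound 2 to compound 3 (within the scatter), shows that moving from 2-fluorophenyl to 3-fluorophenyl on the amide nitrogen leaves this assay unchanged within the scatter.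

Compound 4 `O=C(Nc1cccc(Br)c1)c1ccc2cccc(O)c2n1` has not yet been measured. Its difference from compound 2 is 3-bromophenyl in place of 2-fluorophenyl on an amide-type nitrogen. Among the measured compounds shown here, only the step from compound 2 to compound 3 bears on this change, and it was flat; no measured pair exchanges fluorine for bromine, so that part of the change rests on no comparison here. A moderate rise is expected, a number 0.60 log units higher from compound 2 to compound 4 (beyond the scatter), from compound 2 to compound 4. Compound 4 is estimated at 3.1, with a likely range from 2.7 to 3.5.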

Compound 4, partition coefficient: 2.5
Estimate against measurement, compound 4: 0.60 log units above; the measured number lies below the stated range.
By their numbers in this assay, from the lowest: compounds 1, 2, 3 and 4 (each within the scatter of the next).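

Bromo in place of fluoro on an aromatic carbon gives no change at the digits printed from compound 3 to compound 4 (within the scatter) in this assay, so this is the first exchange of one halogen for another at this position, and the reading stays flat. The wider change, 3-bromophenyl in place of 2-fluorophenyl on an amide-type nitrogen, gives no change at the digits printed from compound 2 to compound 4 (within the scatter), so changing the halogen and its place on the ring together also leaves the reading level in this pair. Nothing available here explains why these readings stay level.

On these data alone, all four compounds carry a phenyl ring with a methoxy, fluoro or bromo group on the amide nitrogen, so it remains open whether an amine or a carboxylic acid on that ring would shift the reading. As far as these compounds go, it also remains open whether a longer chain in place of the phenyl ring would do so.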